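The source may hold more compounds than are shown below. What is called first, only, known or untested is meant among the compounds shown, and "the series" means these compounds.

Measured so far:
- Compound 1, `COc1ccc(-c2c(C)nn3c(NCc4ccc(N(C)C)cc4)cc(C)nc23)cc1OC`: 3.7 in a physicochemical assay for lipophilicity, at pH 7.4; on this read-out lower numbers stand for lower lipophilicity and higher numbers for higher lipophilicity
- Compound 2, `COc1ccc(-c2c(C)nn3c(NCc4cccnc4)cc(C)nc23)cc1OC`: compound 2 gives 4.3
- Compound 3, `COc1ccc(-c2c(C)nn3c(NCc4ccc(N(C)C)cc4)nc(C)nc23)cc1OC`: compound 3 gives 3.9

Compound 1 and compound 2 share a core and differ in one place: pyridin-3-yl in place of 4-(dimethylamino)phenyl on a saturated chain carbon bound to a nitrogen on an aromatic ring. That change moved this assay by a number 0.60 log units higher from compound 1 to compound 2 (beyond the scatter), a step that clears the scatter of the measurement.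

Compound 3 carries a different core; how its core differs from that of compound 1 is not broken down here. Its number in this assay sits close to that of compound 1, within the scatter, so no order between the two can be read. Against compound 2 the gap is larger than the scatter.

Compound 4, `COc1ccc(-c2c(C)nn3c(NCc4cccnc4)nc(C)nc23)cc1OC`, has not been measured. It stands to compound 3 as compound 2 stands to compound 1: pyridin-3-yl in place of 4-(dimethylamino)phenyl on a saturated chain carbon bound to a nitrogen on an aromatic ring. The place of the change reads the same in both pairs, so this is the same change on the second core, and it occurs twice among the compounds considered.

Among the compounds with values here, the expectation for compound 4 in this assay rests on the one measured instance of this change, because the step of a number 0.60 log units higher from compound 1 to compound 2 (beyond the scatter) is the only guide available. The starting point is compound 3, which gives 3.9. The estimated step is a number 0.60 log units higher from compound 3 to compound 4 (beyond the scatter). Compound 4 is therefore expected to come out near 4.5, with a likely range from 4.1 to 4.9.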

Compound 4, distribution coefficient: 4.5
Compound 4: the middle estimate sits on the measured number at the digits printed; the range from low to high includes it.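

Working notes on the series: in this assay, pyridin-3-yl in place of 4-(dimethylamino)phenyl on a saturated chain carbon bound to a nitrogen on an aromatic ring gives a number 0.60 log units higher from compound 3 to compound 4 (beyond the scatter), and the same change on the other core gives a number 0.60 log units higher from compound 1 to compound 2 (beyond the scatter), so across these two matched pairs the step carries from one core to the other at the same size. This shows transfer for this single change on these two cores only; two pairs make no rule for the series, and they say nothing about a further core or about any other exchange of groups at this place. Nothing on hand bears on what lies behind the step, so the agreement between the two pairs stands as an observation and no more.

The compounds shown leave open how the step divides between losing the dimethylamino group and bringing a nitrogen into the aromatic ring, a question that an unsubstituted phenyl at the same place on both cores would address. Also open, on these data alone, is whether the same transfer between the two cores would hold for a carboxylic acid on that ring or for a longer chain in place of the (pyridin-3-yl)methyl.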